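Carboxy-to-tetrazole swap on the pyridine of compound 3

The source may report more compounds than this note shows. Statements on the series, on what has been measured and on what is new or still open speak of the compounds shown alone.

Compound 3 `O=C(O)Cc1ccc(NC(=O)[C@H](CC2CCCC2)n2cnc(C(F)(F)F)c2)nc1` stands at the low end of what has been measured in an in vitro ADME assay on microsomes from liver (Homo sapiens) for metabolic stability; a higher number here means faster removal of the compound, a lower number slower removal. In this assay compound 3 gives < 8 mL/min/kg, which is a limit of the assay rather than a number. Compound 1 `Cc1ccc(NC(=O)[C@H](CC2CCCC2)n2cnc(C(F)(F)F)c2)nc1` is the reference without an acid; in this assay compound 1 gives > 120 mL/min/kg, again a limit. Compound 2 `O=C(O)c1cccc(NC(=O)[C@H](CC2CCCC2)n2cnc(C(F)(F)F)c2)n1` carries the acid directly on the ring; in this assay compound 2 gives < 8 mL/min/kg, also a limit. From the compounds shown here alone, the two steps from the reference are an at least 15-fold lower number from compound 1 to compound 2 (1.17 log units; beyond the scatter) and an at least 15-fold lower number from compound 1 to compound 3 (1.17 log units; beyond the scatter); both end at the limit of < 8 mL/min/kg in this assay, at which 2 of the 3 values shown sit, and start from the limit of > 120 mL/min/kg in this assay, at which 1 of the 3 values shown sits, so their true size is unknown beyond being large.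

Compound 4 `O=C(Nc1ccc(-c2nnn[nH]2)cn1)[C@H](CC1CCCC1)n1cnc(C(F)(F)F)c1` differs from compound 3 by 1H-tetrazol-5-yl in place of carboxymethyl on an aromatic carbon. No measured step covers this change: both shown steps concern a carboxy entering, whereas here the carboxymethyl leaves and a tetrazolyl enters. The shown steps bear on it only in that the acid-bearing compounds 2 and 3 sit at the lower limit. For compound 4 a rise from that limit is expected, of about an at least 1.8-fold higher number from compound 3 to compound 4 (0.27 log units; that floor lies within the scatter), within the scatter or a little beyond. Compound 4 is estimated at 15 mL/min/kg, with a range from 6 mL/min/kg to 40 mL/min/kg.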

Compound 4, clearance: 160 mL/min/kg
The estimate for compound 4 lay 11-fold (1.03 log units) below the measured number, and the stated range ends below it.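

At this aromatic carbon, para to a large group, 1H-tetrazol-5-yl in place of carboxymethyl gives in this assay an at least 20-fold higher number from compound 3 to compound 4 (1.30 log units; beyond the scatter), so the low end reached by the two carboxy-bearing compounds, compound 2 and compound 3, does not extend to every group placed here. From the compounds shown here alone, the step is beyond the scatter, but its true size remains unknown, as it starts from a limit of the assay for compound 3: the limit of < 8 mL/min/kg in this assay, at which 2 of the 4 values shown sit. The step from compound 1 to compound 4 cannot be read, as compound 1 stands at a limit of the assay: the limit of > 120 mL/min/kg in this assay, at which 1 of the 4 values shown sits.

The change from compound 3 to compound 4 replaces the saturated carbon and the carboxy together, so the compounds shown do not separate the loss of that chain carbon from the arrival of the five-membered ring. A 1H-tetrazol-5-ylmethyl group or a carboxy bound directly at this same ring carbon would divide the change into those two parts, while an acylsulfonamide here would test whether the low end extends beyond the carboxy-bearing compounds.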